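Chloro in Place of Nitro on a Weakly Active Core

The compounds below may be only part of what the source reports. "The series", "measured", "known", "first", "only" and "open" are said of these compounds alone.

Of the compounds shown here, three sharing one core have been tested in an ADME assay on BJ cells (Homo sapiens) for antiproliferative activity, with a stated time of 72 h; on this read-out lower numbers stand for an effect already at smaller amounts and higher numbers for an effect only at larger amounts of compound. Compound 1 `COC(=O)c1cc(=O)c2c(OC)cc(OC)cc2n1C` reaches only a limit of the assay, > 37900 nM. Compound 2 `COC(=O)c1cc(=O)c2c(OC)cc(OC)cc2n1S(=O)(=O)c1ccc(C)cc1` gives 139000 nM. Compound 3 `COc1ccc(-c2cc(=O)c3c(OC)cc(OC)cc3n2S(=O)(=O)c2ccc([N+](=O)[O-])cc2)cc1` likewise reaches only a limit of the assay, > 29300 nM. On the numbers shown, compound 3 thus stands at the limit of > 29300 nM in this assay, at which 1 of the 3 values shown sits, and because two of the three values are limits rather than numbers, no step between measured compounds can be read from them.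

Compound 4 `COc1ccc(-c2cc(=O)c3c(OC)cc(OC)cc3n2S(=O)(=O)c2ccc(Cl)cc2)cc1` differs from compound 3 by chloro in place of nitro on an aromatic carbon, para to a large group. With nothing measured along this kind of change, the step from compound 3 to compound 4 in this assay is expected to be none beyond the scatter, and a further limit is the most likely outcome. Compound 4 is therefore estimated at 40000 nM, between 15000 nM and 110000 nM. This estimate means an expected step that the limit leaves unreadable from compound 3 to compound 4.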

Compound 4, half-maximal effective concentration: > 34400 nM
Compound 4 was reported as a limit (the forecaster's own chance of this, stated with the estimate: 75%); the middle value lies beyond the limit too.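

In this assay compound 3 is a limit, > 29300 nM. Compound 4 is a limit as well, > 34400 nM. Among the compounds shown here, no step between compound 3 and compound 4 can therefore be read. The compounds shown leave open whether exchanging 4-nitrophenyl for 4-chlorophenyl changes this read-out at all.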